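Carbamoyl on the aldehyde carbon of compound 1

The source may report more compounds than this note shows. Statements on the series, on what has been measured and on what is new or still open speak of the compounds shown alone.

Two members of this series have numbers in a functional assay on PC-3 cells (Homo sapiens) for inhibition, read by MTT assay, with a stated time of 72 h; on this read-out lower numbers stand for stronger inhibition of growth and higher numbers for weaker inhibition of growth. Compound 1 `CC(C)C[C@@H](C=O)NC(=O)[C@@H](NS(=O)(=O)c1ccc(/N=N/c2ccccc2)cc1)C(C)C` gives 27300 nM in this assay, the higher of the two numbers. Compound 2 `CC(C)C[C@@H](C=O)NC(=O)[C@@H]1CCCN1S(=O)(=O)c1ccc(/N=N/c2ccccc2)cc1` gives 5600 nM in this assay, and the gap between the two numbers is wider than the usual scatter of this assay, so compound 1 stands as the weaker of the two measured compounds.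

Compound 3 `CC(C)C[C@H](NC(=O)[C@@H](NS(=O)(=O)c1ccc(/N=N/c2ccccc2)cc1)C(C)C)C(=O)C(N)=O` has not yet been measured. It differs from compound 1 by carbamoyl in place of hydrogen on a carbonyl carbon, so the formyl of compound 1 becomes a carbamoylcarbonyl. Going by the values given here, no measured pair shows this change, so its effect is unknown from the data. For compound 3 a step from compound 1 of about a 1.5-fold higher number from compound 1 to compound 3 (0.17 log units; within the scatter) is expected, leaning towards a somewhat higher number in this assay, with the scatter leaving room for no change at all. Compound 3 is estimated at 40000 nM in this assay, within a range from 10000 nM to 150000 nM.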

Compound 3, concentration for 50% growth inhibition: 24100 nM
The estimate for compound 3 lay 1.7-fold (0.22 log units) above the measured number, within the range that was stated.
By their numbers in this assay, from the lowest: compound 2; then compounds 3 and 1 (each within the scatter of the next).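

In this assay, going by these compounds alone, the change from formyl to carbamoylcarbonyl gives a 1.1-fold lower number from compound 1 to compound 3 (0.05 log units; within the scatter), the first reading of any change at this place. A carbonyl carbon whose other neighbours are a saturated chain carbon can therefore carry carbamoyl in place of hydrogen with no change in the read-out that can be told from scatter, so at this level of growth inhibition the formyl itself is not needed. No evidence is available that bears on this result.

Still open, going by these compounds, is whether the same change gives a similar step on the core of compound 2, which holds the lower number. Also open, on these data alone, is how other groups on this carbonyl carbon would read, such as a carboxylic acid, a methyl ester or a carbamoyl carrying a longer chain on its nitrogen.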